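The source may hold more compounds than are shown below. What is called first, only, known or untested is meant among the compounds shown, and "the series" means these compounds.

Measured in a functional assay on MCF7 cells (Homo sapiens) for antiproliferative activity, read by MTT assay, with a stated time of 72 h; a lower number here means a stronger inhibitor, a higher number a weaker inhibitor:
- Compound 1 `O=S1(=O)C=Cc2cccc(Nc3ccc(Cl)cc3)c21`: 680 nM
- Compound 2 `Cc1ccc(Nc2cccc3c2S(=O)(=O)C=C3)cc1`: 1890 nM

Compound 2 stands at the high end of this short series, the weaker inhibitor of the two at 1890 nM. The nearest value is that of compound 1, at 680 nM.

The next analogue is compound 3 `COc1ccc(Nc2cccc3c2S(=O)(=O)C=C3)cc1`. The change is methoxy in place of methyl on an aromatic carbon, which is methoxy in place of methyl on an aromatic carbon, para to a large group.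

Among the measured compounds shown here, only one measured step bears on this change, the replacement of chloro by methyl on an aromatic carbon: a 2.8-fold higher number from compound 1 to compound 2 (0.44 log units; beyond the scatter). This step is modest but beyond the scatter. For the measured compounds named here, no measured compound carries a methoxy, so the data do not fix the direction of the new step. In this assay, a step no larger than that modest one is expected, leaning slightly towards a lower number and possibly staying within the scatter. The expected step is a 1.4-fold lower number from compound 2 to compound 3 (0.13 log units; within the scatter). For compound 3 the estimated value is 1400 nM, with an expected range of 550 nM to 3500 nM.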

Compound 3, half-maximal inhibitory concentration: 940 nM
The estimate for compound 3 lay 1.5-fold (0.17 log units) above the measured number; the measured number falls inside the stated range.
By their numbers in this assay, from the lowest: compounds 1, 3 and 2 (each within the scatter of the next, the first and the last beyond it).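

In this assay, methoxy in place of methyl gives a 2.0-fold lower number from compound 2 to compound 3 (0.30 log units; within the scatter), and methoxy in place of chloro gives a 1.4-fold higher number from compound 1 to compound 3 (0.14 log units; within the scatter). Compound 3 therefore cannot be separated from either compound 1 or compound 2, even though those two stand apart, so the methoxy, with its two heavy atoms and a hydrogen-bond acceptor, is accommodated at this aromatic carbon, para to a large group, without a step beyond the scatter from either earlier compound. Nothing available explains why the three compounds fall as they do.

As far as these compounds go, these three compounds span only a narrow range of values, and it remains open whether that range would hold for groups of a different kind at this carbon, such as an amine, a carboxylic acid or a longer chain like ethoxy. They also leave open whether methoxy, chloro and methyl would give the same picture on another carbon of this ring, since all three groups are shown at this one place only.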